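Naphthyl trimethoxyphenyl carbinols: swapping the pendant aromatic arm

The source may report more compounds than this note shows. Statements on the series, on what has been measured and on what is new or still open speak of the compounds shown alone.

Compound 1 `CCOC(=O)C(C)C(O)(c1ccc(OC)c(OC)c1OC)c1cccc2ccccc12` sits at the limit > 20000 nM in a functional assay on MDA-MB-231 cells (Homo sapiens) for inhibition, read by sulforhodamine B assay, with a stated time of 48 h; a higher number here means a weaker inhibitor, a lower number a stronger inhibitor.
Compound 2 `COc1ccc(C(c2ccccc2O)c2cccc3ccccc23)c(OC)c1OC` gives 17700 nM in this assay.
Compound 3 `COc1ccc(C(O)(Cc2ccc(F)cc2)c2cccc3ccccc23)c(OC)c1OC` gives 5440 nM in this assay.

Compound 3 has the lowest of the two numbers given, with compound 2 standing higher by a gap beyond the scatter; the value of compound 1 is a limit only. Compound 4 `COc1ccc(C(O)(C/C=C\c2ccccc2)c2cccc3ccccc23)c(OC)c1OC` differs from compound 3 by 2-phenylethenyl in place of 4-fluorophenyl on a saturated chain carbon, two bonds along the chain from two aromatic carbons and an oxygen on a saturated carbon. Among the measured compounds shown here, the only measured step, an at least 3.6-fold lower number from compound 1 to compound 3 (0.56 log units; beyond the scatter), alters the same chain carbon but exchanges an ester-bearing group for the 4-fluorobenzyl, so it bears only loosely on trading one aromatic arm for another. For the measured compounds named here, no measured pair sets a 4-fluorophenyl against a 2-phenylethenyl, so in this assay no step beyond the scatter is expected: a 1.2-fold lower number from compound 3 to compound 4 (0.08 log units; within the scatter). Compound 4 is estimated at 4500 nM, within 1500 nM to 14000 nM.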

Compound 4, half-maximal inhibitory concentration: 12800 nM
Compound 4: middle estimate off by 2.8-fold (0.45 log units), on the low side; measured number inside the range.
By their numbers in this assay, from the lowest: compound 3; then compounds 4 and 2 (each within the scatter of the next). At a limit, above all of these: compound 1.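

In this assay 2-phenylethenyl in place of 4-fluorophenyl on a saturated chain carbon, two bonds along the chain from two aromatic carbons and an oxygen on a saturated carbon, gives a 2.4-fold higher number from compound 3 to compound 4 (0.37 log units; beyond the scatter) and this modest step makes compound 4 the weaker inhibitor of the two. Both arms carry one six-membered aromatic ring, so an aromatic ring in the arm does not alone set the number. Compound 1 is held only at a limit: the limit of > 20000 nM in this assay, at which 1 of the 4 values shown sits.

From that limit there is an at least 1.5-fold lower number from compound 1 to compound 4 (0.19 log units; that floor lies within the scatter) and this floor shows no difference beyond the scatter. The step from 4-fluorophenyl to 2-phenylethenyl changes the fluorine, the chain length and the double bond together, and these stay unseparated. As far as these compounds go, a plain benzyl or a saturated 3-phenylpropyl arm remains open.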